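The source may hold more compounds than are shown below. What is called first, only, known or untested is meant among the compounds shown, and "the series" means these compounds.

Working notes on the series. Compound 1 `CCN(CC)c1ccc(-c2cc(Cl)cn3c([N+](=O)[O-])c(CS(=O)(=O)c4ccccc4)nc23)cc1` is the reference point. In an ADME assay on HepG2 cells (Homo sapiens) for cytotoxicity, read by MTT assay, with a stated time of 72 h (a lower number here means that less compound is tolerated, a higher number that more compound is tolerated), compound 1 gives > 15600 nM, which is a limit of the assay and not a measured number. Compound 2 `O=[N+]([O-])c1c(CS(=O)(=O)c2ccccc2)nc2c(-c3ccc(O)cc3)cc(Cl)cn12` carries hydroxy in place of diethylamino on an aromatic carbon, and in this assay compound 2 gives > 12500 nM, again a limit. Compound 3 `O=[N+]([O-])c1c(CS(=O)(=O)c2ccccc2)nc2c(-c3ccc(C(F)(F)F)cc3)cc(Cl)cn12` carries trifluoromethyl in place of diethylamino on an aromatic carbon, and in this assay compound 3 gives > 3900 nM, also a limit. The steps among these three cannot be sized: a step that the two limits leave unreadable from compound 1 to compound 2, a step that the two limits leave unreadable from compound 1 to compound 3 and a step that the two limits leave unreadable from compound 2 to compound 3. So compound 1 stands at a limit among values that are all limits, with no ordering readable.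

Compound 4 `O=[N+]([O-])c1c(CS(=O)(=O)c2ccccc2)nc2c(-c3cccs3)cc(Cl)cn12` is not yet measured in this assay. It differs from compound 1 as follows: thiophen-2-yl in place of 4-(diethylamino)phenyl on an aromatic carbon. Within the data shown here, none of the measured steps touches this change, and the three recorded values sit at the limit of > 12500 nM in this assay, at which 1 of the 3 values shown sits, the limit of > 15600 nM in this assay, at which 1 of the 3 values shown sits, and (the limit of > 3900 nM in this assay, at which 1 of the 3 values shown sits), so no step size is available as a guide. The expectation therefore rests on the unchanged core alone. Compound 4 is expected to give 20000 nM in this assay, within 8000 nM to 50000 nM, with a good chance that only a limit is again reported. The step this estimate implies is expected to be a step that the limit leaves unreadable from compound 1 to compound 4.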

Compound 4, half-maximal cytotoxic concentration: > 3900 nM
Compound 4: no number, only a limit; the forecaster's own chance of this, stated with the estimate: 70%; the middle value lies beyond the limit too.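

In this assay compound 4 gives > 3900 nM, which is a limit of the assay and not a number. Its steps to compound 1, compound 2 and compound 3 therefore cannot be read. The compounds shown leave open where the half-maximal cytotoxic concentration of any of the four lies, and whether exchanging these groups changes it at all.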